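A Third Phenyl Added to a Weak Bcl-2-like Binder

This account rests on a few compounds, and the source may have more. Where it says the series, first, only, none or still open, it means among the compounds named here.

Three compounds built on a shared core were tested in an assay on isolated protein for displacement of a labelled ligand from Bcl-2-like protein 2 (Homo sapiens), read by fluorescence polarization; on this read-out lower numbers stand for stronger inhibition and higher numbers for weaker inhibition. Compound 1 `CC(C)C[C@@H](C(=O)O)N1C(=O)/C(=C/c2ccc(Br)cc2)SC1=S` gives 31200 nM in this assay. Compound 2 `C/C(=C1/SC(=S)N([C@@H](CC(C)C)C(=O)O)C1=O)c1ccccc1` gives 58300 nM. Compound 3 `CC(C)C[C@@H](C(=O)O)N1C(=O)C(=C(c2ccccc2)c2ccccc2)SC1=S` gives 61900 nM, the highest of the three numbers, but its gaps to compound 2 and to compound 1 both fall within the scatter of repeated measurements, so no ranking among the three can be drawn from these numbers.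

Compound 4 `CC(C)C[C@@H](C(=O)O)N1C(=O)/C(=C(\c2ccccc2)c2ccc(-c3ccccc3)cc2)SC1=S` differs from compound 3 in a single place: phenyl in place of hydrogen on an aromatic carbon. Within the data shown here, no pair of measured compounds shows a matching change, so the size of this step cannot be read from the series. Because compound 3 stands at 61900 nM and all three measured numbers lie close together, the expected step of a 1.5-fold lower number from compound 3 to compound 4 (0.19 log units; within the scatter) is small, leaning toward a lower number, yet not clearly beyond the scatter. Compound 4 is therefore expected to give about 40000 nM, within a range from 15000 nM to 100000 nM.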

Compound 4, inhibition constant: 6980 nM
Estimate against measurement, compound 4: 5.7-fold (0.76 log units) above; the whole stated range lies above it.
By their numbers in this assay, from the lowest: compound 4; then compounds 1, 2 and 3 (each within the scatter of the next).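

In this assay, phenyl in place of hydrogen on an aromatic carbon, para to a large group, gives an 8.9-fold lower number from compound 3 to compound 4 (0.95 log units; beyond the scatter) and so lies beyond the scatter. Among these compounds, the numbers of the three earlier compounds all lie within the scatter of one another, so they showed no step of this kind, whereas this change shows that the position can respond and that a second aromatic ring of carbon only is tolerated there. Nothing measured here bears on why the number falls.

The compounds shown leave open whether phenyl is needed at this carbon or whether a smaller group, such as methoxy, would lower the number as well. They also leave open whether a pyridyl ring, which carries a ring nitrogen, would do the same as phenyl.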